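A Dichlorophenyl Swap on a Weak Growth Inhibitor

A few compounds are considered here, and "the series" means these few. Any claim that something is new, unique, unknown or untested is made for them only; others in the source may bear on it.

Of the compounds shown here, two sharing one core have been tested in a functional assay on HCT-15 cells (Homo sapiens) for cytotoxicity; a higher number here means a weaker inhibitor of growth, a lower number a stronger inhibitor of growth. Compound 1, with structure `Cc1ccc(S(=O)(=O)N2c3ccccc3CC2C(=O)Nc2ccc(C(F)(F)F)cc2)cc1`, gives in this assay > 10000 nM, which is a limit of the assay rather than a number, as noted in the limit of > 10000 nM in this assay, at which 1 of the 2 values shown sits. Within the data shown here, compound 2, with structure `CC(NC(=O)OC(C)(C)C)C(=O)N1c2ccccc2CC1C(=O)Nc1ccc(C(C)(F)F)cc1`, is the only compound with an actual number, and in this assay compound 2 gives 6510 nM. Compound 3, with structure `CC(NC(=O)OC(C)(C)C)C(=O)N1c2ccccc2CC1C(=O)Nc1cc(Cl)cc(Cl)c1`, has not yet been measured. It differs from compound 2 in one place: 3,5-dichlorophenyl in place of 4-(1,1-difluoroethyl)phenyl on an amide-type nitrogen. Among the measured compounds shown here, no measured pair shows what such a swap does here, so the expectation rests on the single number of compound 2 alone. The step of a 1.3-fold lower number from compound 2 to compound 3 (0.11 log units; within the scatter) is expected to be small, within or barely beyond the scatter, with no firm direction. Compound 3 is therefore estimated at 5000 nM, expected to fall between 1500 nM and 15000 nM.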

Compound 3, concentration for 50% growth inhibition: 4330 nM
Estimate against measurement, compound 3: 1.2-fold (0.06 log units) above, and the stated range covers the measured number.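

In this assay, putting 3,5-dichlorophenyl in place of 4-(1,1-difluoroethyl)phenyl on the amide-type nitrogen gives a 1.5-fold lower number from compound 2 to compound 3 (0.18 log units; within the scatter). Among these compounds, this is the first measured comparison at this position, with the rest of the molecule held the same, and it shows that these two differently substituted phenyl groups cannot be told apart in this test of growth inhibition. Nothing at hand bears on why the two groups read alike.

One pair cannot show whether any change at this position moves the number beyond the scatter. A phenyl ring carrying an amine or a carboxylic acid, or a longer alkyl chain in place of the ring, would test how much this position tolerates.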